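A few compounds are considered here, and "the series" means these few. Any claim that something is new, unique, unknown or untested is made for them only; others in the source may bear on it.

Values in an ADME assay on Huh-7 cells (Homo sapiens) for cytotoxicity, read by MTT assay, with a stated time of 96 h; a higher number here means that more compound is tolerated, a lower number that less compound is tolerated:
Compound 1 `COc1cc(/N=C/c2cccs2)ccc1-c1cnco1`: > 100000 nM, a limit.
Compound 2 `COc1cc(NCc2ccc(Cl)s2)ccc1-c1cnco1`: 43200 nM.
Compound 3 `COc1cc(/N=C/c2ccncc2)ccc1-c1cnco1`: > 100000 nM, a limit.

Going by the values given here, compound 2 carries the only number in this assay so far. The other two values are the limit of > 100000 nM in this assay, at which 2 of the 3 values shown sit.

Compound 4 `COc1cc(NCc2ccsc2)ccc1-c1cnco1` differs from compound 2 by one change: thiophen-3-yl in place of 5-chlorothiophen-2-yl on a saturated chain carbon bound to a nitrogen on an aromatic ring. Among the compounds with values here, the only measured step, a step that the two limits leave unreadable from compound 1 to compound 3, has no readable size and lies on a carbon with a double bond to nitrogen, not on a saturated chain carbon. It therefore gives no size for this change, and no step beyond the usual scatter is expected in this assay. The expected step is a 1.3-fold higher number from compound 2 to compound 4 (0.10 log units; within the scatter). Compound 4 is estimated at 55000 nM, with an expected range of 22000 nM to 100000 nM.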

Compound 4, half-maximal cytotoxic concentration: 63100 nM
Beside the measured number, compound 4's estimate is 1.1-fold (0.06 log units) below it, and the stated range covers the measured number.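

In this assay, the saturated chain carbon bound to a nitrogen on an aromatic ring now has a readable step, with a 1.5-fold higher number from compound 2 to compound 4 (0.16 log units; within the scatter) for the exchange of 5-chlorothiophen-2-yl for thiophen-3-yl. This exchange removes the chlorine and alters the thiophene attachment together, and the two numbers stay within the scatter of each other, so neither part can be read alone.

Still open, from the compounds shown here alone, is whether pyridin-4-yl on this saturated chain carbon, or an amine or a carboxylic acid on the thiophene, gives a step beyond the scatter. Steps involving the remaining compounds cannot be read: the limit of > 100000 nM in this assay, at which 2 of the 4 values shown sit.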